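Side-chain variation on the amide-linked ester series

The source may hold more compounds than are shown below. What is called first, only, known or untested is meant among the compounds shown, and "the series" means these compounds.

Measured so far:
compound 1 `O=C(CN(c1ncnc2c1ncn2C1CCCCO1)C1CC1)N[C@@H](CCC(=O)OCc1ccccc1)C(=O)OCc1ccccc1` — 34.7%
compound 2 `O=C(CN(c1ncnc2c1ncn2C1CCCCO1)C1CC1)NCC(=O)OCc1ccccc1` — 40.4%
compound 3 `O=C(CN(c1ncnc2c1ncn2C1CCCCO1)C1CC1)N[C@@H](CC(=O)OCc1ccccc1)C(=O)OCc1ccccc1` — 38.2%

The three measured compounds share one core and differ only in the substituent on the saturated chain carbon bound to the amide-type nitrogen and the carbonyl carbon. In a functional assay on the whole organism (Tail, strain ICR) with Mus musculus as the target, in the tail flick test, with a stated time of 60 min, at a dose of 25 umol/kg by the oral route (a lower number here means a weaker effect, a higher number a stronger effect of the compound at the dose given), compound 3 gives 38.2% and stands second highest of the three, nearest to compound 2 and furthest from compound 1, both gaps within the scatter. The steps recorded so far, a number 5.7 percentage points higher from compound 1 to compound 2 (within the scatter), a number 3.5 percentage points higher from compound 1 to compound 3 (within the scatter) and a number 2.2 percentage points lower from compound 2 to compound 3 (within the scatter), are all within the scatter: removing or shortening the ester-bearing side chain at this carbon moved the read-out by nothing that can be told from noise.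

Compound 4 `CSCC[C@H](NC(=O)CN(c1ncnc2c1ncn2C1CCCCO1)C1CC1)C(=O)OCc1ccccc1` carries a different change at the same place: (methylsulfanyl)methyl in place of benzyloxycarbonyl on a saturated chain carbon, two bonds along the chain from an amide-type nitrogen and a carbonyl carbon. Within the data shown here, no measured step exchanges an ester-bearing chain for a sulfur-bearing one, so the three recorded steps bear on this one only through the place, where every change so far stayed within the scatter. No step beyond the scatter is therefore expected, in either direction. For compound 4 the expected value in this assay is 38%, with a range from 24% to 52%, that is an expected step of a number 0.2 percentage points lower from compound 3 to compound 4 (within the scatter).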

Compound 4, a percentage reported as activity, at one dose (the size of the read-out at that dose, not a potency): 41%
Compound 4: middle estimate off by 3 percentage points, on the low side, and the stated range covers the measured number.
By their numbers in this assay, from the lowest: compounds 1, 3, 2 and 4 (each within the scatter of the next).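

In this assay, the exchange of benzyloxycarbonyl for (methylsulfanyl)methyl at this place brings in sulfur and removes a six-membered aromatic ring of carbon only, yet it gives a number 2.8 percentage points higher from compound 3 to compound 4 (within the scatter), so a change of this kind leaves the read-out where the ester-bearing chains left it. The two further comparisons agree: 2-(methylsulfanyl)ethyl in place of hydrogen gives a number 0.6 percentage points higher from compound 2 to compound 4 (within the scatter), and methylsulfanyl in place of benzyloxycarbonyl, three bonds along the chain from an amide-type nitrogen and a carbonyl carbon, gives a number 6.3 percentage points higher from compound 1 to compound 4 (within the scatter), so across these four compounds neither a sulfur-bearing chain nor an ester-bearing chain can be told from hydrogen on this carbon. Nothing measured alongside these numbers accounts for why the read-out stays level at this place.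

Still open, going by these compounds, is whether a carboxylic acid in place of the benzyl ester, a primary amine at the end of the side chain, or a longer alkyl chain on this carbon would give a step beyond the scatter. Since this assay reports one dose only, the size of the read-out at that dose also leaves open whether these compounds would separate at other doses.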